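Adding an ethyl group to an amide nitrogen

The source may hold more compounds than are shown below. What is called first, only, known or untested is meant among the compounds shown, and "the series" means these compounds.

In a functional assay on L02 cells (Homo sapiens) for inhibition (on this read-out higher numbers stand for weaker inhibition and lower numbers for stronger inhibition), compound 1 `O=C(CC(CC(=O)NC1Cc2ccccc2C1)c1ccc(Cl)cc1)NCCN1CCCCC1` gives 70400 nM. Compound 2 `O=C(CC(CC(=O)NC1Cc2ccccc2C1)c1ccc(Cl)cc1)NCCN1CCCC1` gives 89400 nM, and these two numbers lie within the scatter of each other. Compound 3 `O=C(CC(CC(=O)NC1Cc2ccccc2C1)c1ccccc1)NCCN1CCCCC1` gives > 100000 nM, which is a limit of the assay and not a number. Among the measured compounds shown here, compound 1 therefore shares its place on the scale with compound 2, and no measured compound stands clearly apart from it.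

Compound 4 `CCN(C(=O)CC(CC(=O)NCCN1CCCCC1)c1ccc(Cl)cc1)C1Cc2ccccc2C1` differs from compound 1 by ethyl in place of hydrogen on an amide-type nitrogen. Two measured steps offer a comparison, though both lie elsewhere in the molecule. Pyrrolidin-1-yl in place of piperidin-1-yl gives a 1.3-fold higher number from compound 1 to compound 2 (0.10 log units; within the scatter). Hydrogen in place of chloro gives an at least 1.4-fold higher number from compound 1 to compound 3 (0.15 log units; that floor lies within the scatter). The first step lies within the scatter, and so does the floor of the second. On these data alone, neither tests this nitrogen, so the evidence is indirect and the direction remains open. No change beyond the scatter is expected, and the estimated step is a 1.1-fold higher number from compound 1 to compound 4 (0.06 log units; within the scatter). For compound 4, the expected value in this assay is 80000 nM, with an estimated range of 35000 nM to 140000 nM.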

Compound 4, half-maximal inhibitory concentration: 84200 nM
For compound 4 the middle estimate is 1.1-fold (0.02 log units) below the measured one; low and high end bracket the measured number.
By their numbers in this assay, from the lowest: compounds 1, 4 and 2 (each within the scatter of the next). At a limit, above all of these: compound 3.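

Among the compounds shown here, the earlier steps changed only the piperidin-1-yl group and the chloro group, so compound 4 is the first test of the amide nitrogen that carries the saturated ring carbon. In this assay, replacing the amide hydrogen with ethyl gives a 1.2-fold higher number from compound 1 to compound 4 (0.08 log units; within the scatter), so adding these two carbons, which leaves this nitrogen with no hydrogen, produces no change that can be told apart from the scatter. Little room remains at the upper end of this assay, however, so a much larger upward step could not be sized as a number: the limit of > 100000 nM in this assay, at which 1 of the 4 values shown sits.

The compounds shown leave open how this nitrogen responds to other groups, such as methyl, a longer propyl chain, or a chain ending in an amine or a carboxylic acid. They also leave open whether ethyl in the same place would give a similarly small step in compound 2, which carries pyrrolidin-1-yl, or in compound 3, which has hydrogen in place of chloro.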